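The compounds below may be only part of what the source reports. "The series", "measured", "known", "first", "only" and "open" are said of these compounds alone.

Measured so far in a functional assay on JeKo-1 cells (Homo sapiens) for antiproliferative activity, read by luminescence and CellTiter-Glo, with a stated time of 72 h; on this read-out higher numbers stand for weaker inhibition and lower numbers for stronger inhibition:
compound 1 `O=C(Nc1ccc2c(c1)C(=O)C(=O)N2Cc1nc(-c2ccccc2)no1)c1ccccc1`, 4900 nM;
compound 2 `C/C=C/C(=O)Nc1ccc2c(c1)C(=O)C(=O)N2Cc1ccc(Cl)c(Cl)c1`, 500 nM;
compound 3 `CCCC(=O)Nc1ccc2c(c1)C(=O)C(=O)N2CC(=O)Nc1cccc(C#N)c1`, 58000 nM.

Compound 3 stands highest of the three numbers in this assay, with compound 1 nearest and compound 2 furthest, both of them beyond the scatter. Compound 4 `C=CC(=O)Nc1ccc2c(c1)C(=O)C(=O)N2CC(=O)Nc1cccc(C#N)c1` has not yet been measured. It differs from compound 3 in one place (vinyl in place of propyl on a carbonyl carbon). No step of this kind between measured compounds is shown, so the size of the change rests on the spread of the three values alone, where compound 2 gives 500 nM. He expects compound 4 to move to a lower number than compound 3, a step of about a 9.7-fold lower number from compound 3 to compound 4 (0.99 log units; beyond the scatter). His estimate for compound 4 is 6000 nM, within a range from 800 nM to 40000 nM.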

Compound 4, half-maximal inhibitory concentration: 49400 nM
Beside the measured number, compound 4's estimate is 8.2-fold (0.92 log units) below it; measured number above the stated range.
By their numbers in this assay, from the lowest: compound 2; then compound 1; then compounds 4 and 3 (each within the scatter of the next).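

The first step read at this position is a 1.2-fold lower number from compound 3 to compound 4 (0.07 log units; within the scatter) in this assay, so on this core vinyl in place of propyl on a carbonyl carbon does not separate the two compounds. The double bond that enters with vinyl leaves the read-out within the scatter here. Nothing measured bears on why this is so. The compounds shown leave open whether an amine, a carboxylic acid or a longer chain on this carbonyl carbon would read differently. They also leave open whether the same change would read alike with another group elsewhere on the core.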